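Adding a Nitro Group to Compound 2

The compounds below may be only part of what the source reports. "The series", "measured", "known", "first", "only" and "open" are said of these compounds alone.

Compound 2 (`O=C(CCCCC(S)CCS)Nc1cccc(C(F)(F)F)c1`) offers no number to start from: in a functional assay on PC-3 cells (Homo sapiens) for inhibition, read by MTT assay, with a stated time of 24 h, tested at 0.1 ug/mL (a lower number here means less inhibition of growth, a higher number more inhibition of growth at the concentration tested), compound 2 is recorded as "not determined" (no result reported). The nearest available figure comes from compound 1 (`O=C(CCCCC1CCSS1)Nc1ccc([N+](=O)[O-])c(C(F)(F)F)c1`), and in this assay compound 1 gives 5.37%, a small amount of growth inhibition at the single concentration tested. Compound 3 (`O=C(CCCCC(S)CCS)Nc1ccc([N+](=O)[O-])c(C(F)(F)F)c1`) has not yet been measured. It differs from compound 2 by one structural change: nitro in place of hydrogen on an aromatic carbon. The nitro group takes the place of a hydrogen on an aromatic carbon, ortho to a trifluoromethyl group and para to a large group.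

Among the measured compounds shown here, no measured pair shows what this change does, so the data give no size for the step. In this assay, no shift beyond the usual scatter is expected from the low level seen so far, and any small shift would more likely be upward. The expectation rests on compound 1, which also carries the nitro group and stands at 5.37%. For compound 3, the estimated value is 8%, with an expected range of 0% to 22%.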

Compound 3, percent growth inhibition at one concentration: 8.06%
Beside the measured number, compound 3's estimate is 0.1 percentage points below it; measured number inside the range.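

With the nitro group in place on both compounds, the comparison in this assay gives a number 2.7 percentage points higher from compound 1 to compound 3 (within the scatter) for replacing the five-membered non-aromatic ring of compound 1 with the open group of compound 3 on the same saturated chain carbon. At this concentration, the closed and open forms of that chain end therefore cannot be told apart, and compound 3 stays at the low level already seen for compound 1. Going by these compounds, the position on the aromatic ring that carries nitro now has a value with the open chain end as well, but compound 2 has no number, so the step from hydrogen to nitro cannot be read and its size remains unknown.

The compounds shown leave open whether an amine or a nitrile at the same aromatic position, ortho to the trifluoromethyl group, would give a different reading from nitro. They also leave open whether a longer chain between the carbonyl and the sulfur-bearing end would change the picture. No independent measurement is available to explain these readings.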